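Chloro to pyridinyl on the benzyl ether of compound 1

A few compounds are considered here, and "the series" means these few. Any claim that something is new, unique, unknown or untested is made for them only; others in the source may bear on it.

Measured so far:
- compound 1, `CC(C)(N)C(=O)N[C@H](COCc1ccccc1Cl)c1nnnn1CCOC(=O)NCCCCO`: 0.45 nM
- compound 2, `CC(C)(N)C(=O)N[C@H](COCC1CCCCC1)c1nnnn1CCOC(=O)NCCCCO`: 1.66 nM

In a functional assay on cells for inhibition of growth hormone secretagogue receptor type 1 (Homo sapiens), read by FLIPR and calcium flux (a lower number here means that less compound is needed, a higher number that more compound is needed for the effect), compound 1 gives 0.45 nM, the lowest of the two numbers shown. Within the data shown here, compound 2, `CC(C)(N)C(=O)N[C@H](COCC1CCCCC1)c1nnnn1CCOC(=O)NCCCCO`, gives 1.66 nM in this assay; the only measured step is a 3.7-fold higher number from compound 1 to compound 2 (0.57 log units; beyond the scatter), a change at the saturated chain carbon bound to an oxygen on a saturated carbon.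

Compound 3, `CC(C)(N)C(=O)N[C@H](COCc1ccccc1-c1cccnc1)c1nnnn1CCOC(=O)NCCCCO`, is not yet measured. It differs from compound 1 as follows: pyridin-3-yl in place of chloro on an aromatic carbon. The change sits on an aromatic carbon of a six-membered aromatic ring of carbon only, ortho to a large group.

Among the measured compounds shown here, no measured step replaces a substituent on that ring; the step from compound 1 to compound 2 shows only that the group at this end of the ether matters, and that exchanging 2-chlorophenyl for cyclohexyl moved the number beyond the scatter. With a larger group entering at the same end, a modest rise in the number is expected, a 3.3-fold higher number from compound 1 to compound 3 (0.52 log units; beyond the scatter), with wide uncertainty. Compound 3 is therefore estimated at 1.5 nM in this assay, expected between 0.4 nM and 6 nM.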

Compound 3, half-maximal effective concentration: 1.18 nM
Compound 3: middle estimate off by 1.3-fold (0.10 log units), on the high side; measured number inside the range.
By their numbers in this assay, from the lowest: compound 1; then compounds 3 and 2 (each within the scatter of the next).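

In this assay, the aromatic carbon that carries chloro in compound 1 accepts pyridin-3-yl, a six-membered aromatic ring in place of a single chlorine, at the cost of a modest rise (a 2.6-fold higher number from compound 1 to compound 3 (0.42 log units; beyond the scatter)), and compound 3 stays at 1.18 nM. Among these compounds, this is the first change made on the benzyl ring itself, and it brings the number level with the cyclohexyl ether (a 1.4-fold lower number from compound 2 to compound 3 (0.15 log units; within the scatter)), so 2-(pyridin-3-yl)phenyl and cyclohexyl cannot be told apart at this end of the ether, while the 2-chlorophenyl of compound 1 keeps the lowest number of the three, with both of its steps beyond the scatter. Nothing available here accounts for either step.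

Open, as far as these compounds go, is whether the ring nitrogen of pyridin-3-yl plays any part in the number, a question that a plain phenyl or a pyridin-4-yl at the same carbon would address. Among the compounds shown here, also open is how a small group such as fluoro, methyl or an amine compares with chloro at this place, since only one group smaller than the pyridine ring appears there.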